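A few compounds are considered here, and "the series" means these few. Any claim that something is new, unique, unknown or untested is made for them only; others in the source may bear on it.

Working notes on the hydrazone series.

Of the compounds shown here, three have been measured in a physicochemical assay on A549 cells for solubility, read by microscopy, with a stated time of 24 h; on this read-out lower numbers stand for stronger inhibition and higher numbers for weaker inhibition. Compound 1 `O=C(N/N=C/c1ccco1)c1cc(-c2ccccc2)nn1Cc1ccccc1` gives 8780 nM. Compound 3 `O=C(N/N=C/c1ccccc1O)c1cc(-c2ccccc2)nn1Cc1ccccc1` gives 650 nM, and compound 2 `O=C(N/N=C/c1ccccc1O)c1cc(-c2ccc(Cl)cc2)nn1Cc1ccc(Cl)nc1` gives 500 nM. Within the data shown here, the single one-place step so far, a 14-fold lower number from compound 1 to compound 3 (1.13 log units; beyond the scatter), is the only large movement in the set. Compound 3 therefore stands far from compound 1 and close to compound 2: the two values of compound 3 and compound 2 lie within the scatter of each other, so no order between them can be claimed.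

The next compound, compound 4 `O=C(N/N=C/c1ccccc1O)c1cc(-c2ccc(Cl)cc2)nn1Cc1ccccc1`, is reached from compound 3 by one change: chloro in place of hydrogen on an aromatic carbon, para to a large group. Among the measured compounds shown here, no measured one-place step covers exactly this change. For the measured compounds named here, the only pair that speaks to it is compound 2 against compound 3, where the 4-chlorophenyl is already present alongside a second change on the other arm, and the two values sit within the scatter. On that basis the step in this assay from compound 3 to compound 4 is expected to stay within the scatter, with no clear direction, a 1.2-fold lower number from compound 3 to compound 4 (0.07 log units; within the scatter).

For compound 4 the estimated value in this assay is 550 nM, within a range from 280 nM to 1100 nM.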

Compound 4, half-maximal inhibitory concentration: 680 nM
Estimate against measurement, compound 4: 1.2-fold (0.09 log units) below; the range from low to high includes it.
By their numbers in this assay, from the lowest: compounds 2, 3 and 4 (each within the scatter of the next); then compound 1.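

Notes on the 4-chlorophenyl position: in this assay the chloro group on this aromatic carbon, para to a large group, now has a one-place step of its own, and a 1.0-fold higher number from compound 3 to compound 4 (0.02 log units; within the scatter) shows no readable effect of phenyl to 4-chlorophenyl with the 2-hydroxyphenyl group and the rest of the core of compound 3 held constant. The other arm can now also be read alone, since a 1.4-fold higher number from compound 2 to compound 4 (0.13 log units; within the scatter) leaves no readable difference between phenyl and 6-chloropyridin-3-yl on the saturated chain carbon bound to an aromatic nitrogen, with 4-chlorophenyl present in both compounds. Neither step approaches a 14-fold lower number from compound 1 to compound 3 (1.13 log units; beyond the scatter) in size, so among the three one-place steps, only the exchange of furan-2-yl for 2-hydroxyphenyl moves the number beyond the scatter.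

No evidence is at hand to account for these results. Open questions are whether the same insensitivity holds for a methoxy group, an amine or a carboxylic acid on this aromatic carbon, and whether chloro would also leave the number unmoved in a compound carrying furan-2-yl instead of 2-hydroxyphenyl.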